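Allyl in Place of Ethyl on the Core Nitrogen

The source may hold more compounds than are shown below. What is called first, only, known or untested is meant among the compounds shown, and "the series" means these compounds.

Of the compounds shown here, three built on one shared core have been tested in a functional assay for agonist activity at 5-hydroxytryptamine receptor 4 (Cavia porcellus); a higher number here means a larger maximal response, a lower number a smaller maximal response. Compound 1 `CC(C)n1c(=O)n(C(=O)NCCN2CCN(C)CC2)c2cc(F)ccc21` gives 0.67. Compound 3 `CCCN1CCN(CCNC(=O)n2c(=O)n(C(C)C)c3ccccc32)CC1` gives 0.68. Within the data shown here, compound 2 `CCn1c(=O)n(C(=O)NCCN2CCN(C)CC2)c2ccccc21` reaches only < 0.3, which is a limit of this assay rather than a number, and compound 2 is the one compound sitting at the limit of < 0.3 in this assay, at which 1 of the 3 values shown sits. So compound 2 stands at the bottom of the values shown, while compound 1 and compound 3 lie within the scatter of each other.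

Compound 4 `C=CCn1c(=O)n(C(=O)NCCN2CCN(C)CC2)c2ccccc21` has not yet been measured. It differs from compound 2 in one place: vinyl in place of methyl on a saturated chain carbon bound to an aromatic nitrogen. Among the measured compounds shown here, no pair of measured compounds differs in exactly one place, so no step of known size is available. The expectation is a modest rise from compound 2 to compound 4 of a number at least 0.10 higher from compound 2 to compound 4 (that floor lies within the scatter) in this assay, since compound 1 and compound 3, which carry larger groups on that nitrogen, sit clearly higher. Compound 4 is estimated at 0.4, with a range from 0.2 to 0.65.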

Compound 4, intrinsic activity: the largest response reached, as a fraction of the reference agonist's: 0.63
Compound 4: middle estimate off by 0.23, on the low side, and the stated range covers the measured number.
By their numbers in this assay, from the lowest: compounds 4, 1 and 3 (each within the scatter of the next). At a limit, below all of these: compound 2.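

In this assay, allyl in place of ethyl, which is vinyl in place of methyl on a saturated chain carbon bound to an aromatic nitrogen, gives a number at least 0.33 higher from compound 2 to compound 4 (beyond the scatter). Among these compounds, this is the first step of known size at this place, and it shows that one change of a single added carbon and one double bond, with the rest of the molecule untouched, is enough to lift the maximal response beyond the scatter. The step is a floor rather than an exact size, because compound 2 sits at a limit: the limit of < 0.3 in this assay, at which 1 of the 4 values shown sits.

The compounds shown leave open whether the double bond or the added carbon carries this step, and a saturated propyl chain at this place would tell the two apart. Also open, from the compounds shown here alone, is how a longer chain or a cyclopropyl group at the same place would behave.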